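Adding (2-methylphenyl)carbonyl to compound 2

The source may report more compounds than this note shows. Statements on the series, on what has been measured and on what is new or still open speak of the compounds shown alone.

Values in a functional assay on HCT-116 cells (Homo sapiens), read by crystal violet staining, with a stated time of 6 days; a higher number here means a weaker inhibitor of growth, a lower number a stronger inhibitor of growth:
- compound 1 `CCCC(=O)Oc1cc(O)c2c(c1)O[C@H](c1ccc(OC)c(O)c1)CC2=O` gives 12000 nM
- compound 2 `COc1ccc([C@@H]2CC(=O)c3c(O)cc(OC(=O)c4ccccc4C)cc3O2)cc1O` gives 22900 nM

Compound 2 stands within the scatter of compound 1. Compound 3 `COc1ccc([C@@H]2CC(=O)c3c(O)cc(OC(=O)c4ccccc4C)cc3O2)cc1OC(=O)c1ccccc1C` differs from compound 2 by (2-methylphenyl)carbonyl in place of hydrogen on an oxygen on an aromatic ring, which turns hydroxy into ((2-methylphenyl)carbonyl)oxy. Among the compounds with values here, no step at this oxygen has been measured. Within the data shown here, the only measured step, a 1.9-fold higher number from compound 1 to compound 2 (0.28 log units; within the scatter), was a change on a carbonyl carbon and offers limited guidance. On that basis, no step beyond the scatter is expected in this assay, in either direction. The expected step is a 1.1-fold higher number from compound 2 to compound 3 (0.04 log units; within the scatter). The estimate for compound 3 is 25000 nM, with an expected range of 9000 nM to 70000 nM.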

Compound 3, concentration for 50% growth inhibition: 48700 nM
The estimate for compound 3 lay 1.9-fold (0.29 log units) below the measured number; the range from low to high includes it.
By their numbers in this assay, from the lowest: compounds 1 and 2 (each within the scatter of the next); then compound 3.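

Putting (2-methylphenyl)carbonyl in place of hydrogen on this oxygen on an aromatic ring gives a 2.1-fold higher number from compound 2 to compound 3 (0.33 log units; beyond the scatter) in this assay, a modest weakening of growth inhibition and the first step read at this oxygen. On this single pair, the free hydroxy gives the stronger inhibitor of growth, and the larger ester remains measurable in the assay. Nothing available explains the step.

Going by these compounds, whether a butanoyl ester or a methyl ether at this oxygen would give a similar step remains open. So does whether an amine-bearing ester would differ from the free hydroxy.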